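From phenyl to 2-chlorophenyl at fixed configuration

The compounds below may be only part of what the source reports. "The series", "measured", "known", "first", "only" and "open" are said of these compounds alone.

In a functional assay on QGY cells (Homo sapiens) for cytotoxicity, read by MTT assay, with a stated time of 48 h (on this read-out lower numbers stand for stronger inhibition and higher numbers for weaker inhibition), compound 1 `CCOC(=O)C1(C(=O)Nc2ccccc2)CC1c1cc(OC)c(OC)c(OC)c1` gives 59300 nM; > 100000 nM (2 entries), entries that do not reduce to one number. Compound 2 `CCOC(=O)[C@]1(C(=O)Nc2ccccc2)C[C@H]1c1cc(OC)c(OC)c(OC)c1` gives > 100000 nM, which is a limit and not a number. For the measured compounds named here, compound 3 `CCOC(=O)[C@]1(C(=O)Nc2ccccc2)C[C@@H]1c1cc(OC)c(OC)c(OC)c1` gives 38100 nM, the only single value among the three entries, and it is the starting point here.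

Going by the values given here, the one measured step is an at least 2.6-fold lower number from compound 2 to compound 3 (0.41 log units; beyond the scatter). It comes with the fact that compounds 2 and 3 differ only in the configuration as drawn, so it speaks to configuration only.

Compound 4 `CCOC(=O)[C@]1(C(=O)Nc2ccccc2Cl)C[C@@H]1c1cc(OC)c(OC)c(OC)c1` keeps the configuration of compound 3 and carries chloro in place of hydrogen on an aromatic carbon. This is chloro in place of hydrogen on an aromatic carbon, ortho to a large group, turning phenylcarbamoyl into (2-chlorophenyl)carbamoyl. Among the compounds with values here, no measured compound varies this aromatic ring, so the configuration step gives no size to carry over.

With nothing pointing either way in this assay, no step beyond the scatter is expected, and the estimate reads a 1.2-fold lower number from compound 3 to compound 4 (0.08 log units; within the scatter). A report as a limit remains possible, given (the limit of > 100000 nM in this assay, at which 1 of the 3 values shown sits). For compound 4 the expected value is 32000 nM, with an estimated range from 11000 nM to 90000 nM.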

Compound 4, half-maximal inhibitory concentration: 34700 nM
Compound 4: the middle estimate sits 1.1-fold (0.04 log units) below what was measured, within the range that was stated.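

In this assay, for the compounds shown here, the earlier compounds changed only configuration, so this is the first measured change on the aromatic ring of the phenylcarbamoyl group, and it gives no step beyond the scatter (a 1.1-fold lower number from compound 3 to compound 4 (0.04 log units; within the scatter)). At the configuration of compound 3, this position therefore accepts chloro in place of hydrogen on an aromatic carbon, ortho to a large group, without a change in the read-out that can be told apart from repeat measurements, and compound 4 is reported as a single value, not as a limit. The available evidence concerns configuration and the assay limit, so nothing in it bears on this result.

One substituent at one place cannot show whether this position is generally indifferent to substitution, and a methoxy group, a trifluoromethyl group or an amine could still behave differently there. The result also leaves open whether the 2-chlorophenyl group would give the same outcome at the configuration of compound 2, and whether any change on this ring can bring the series beyond the scatter from compound 3.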